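The source may hold more compounds than are shown below. What is called first, only, known or untested is meant among the compounds shown, and "the series" means these compounds.

Measured so far:
compound 1, `COc1ccc(C2N=C(SCc3ccccc3)NC(C)=C2C(=O)Nc2ccc(F)cc2)cc1OC`: 11.8%
compound 2, `COc1ccc(C2N=C(SCc3ccc(Cl)cc3)NC(C)=C2C(=O)Nc2ccc(F)cc2)cc1OC`: 24.1%

Compound 1 and compound 2 share a core and differ only in a substituent on the benzyl ring. In a functional assay on the whole organism (artery, strain albino) with Rattus norvegicus as the target, with a stated time of 240 min, at a dose of 10 mg/kg by the oral route (a higher number here means more inhibition at the dose given (going by the name of the read-out), a lower number less inhibition), compound 1 gives 11.8% and compound 2 gives 24.1%, so compound 2 stands highest of the two numbers, the step being a number 12.3 percentage points higher from compound 1 to compound 2 (beyond the scatter).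

Compound 3, `COc1ccc(C2N=C(SCc3ccc(F)cc3)NC(C)=C2C(=O)Nc2ccc(F)cc2)cc1OC`, is not yet measured. It differs from compound 2 in one place: fluoro in place of chloro on an aromatic carbon, the change sitting para to a large group on the six-membered aromatic ring of carbon only.

For the measured compounds named here, the only step that bears on this is the one from compound 1 to compound 2, where chloro in place of hydrogen raised inhibition modestly. Fluoro is a halogen as chloro is, but the data hold no fluoro analogue at this place, so the direction is uncertain. Compound 3 is therefore expected to fall between the two measured numbers, an estimated step of a number 7.1 percentage points lower from compound 2 to compound 3 (within the scatter) that may well lie within the scatter. Compound 3 is estimated at 17%, with a range from 8% to 28%.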

Compound 3, a percentage reported as inhibition, in the whole organism at one dose (the size of the read-out at that dose, not a potency): 28.7%
Compound 3: middle estimate off by 11.7 percentage points, on the low side; the measured number lies above the stated range.
By their numbers in this assay, from the lowest: compound 1; then compounds 2 and 3 (each within the scatter of the next).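

In this assay, the change from chloro to fluoro at this place on the benzyl ring gives a number 4.6 percentage points higher from compound 2 to compound 3 (within the scatter), so the two halogens cannot be told apart here. Fluoro in place of hydrogen gives a number 16.9 percentage points higher from compound 1 to compound 3 (beyond the scatter), which shows that the rise first seen with chloro is not confined to chloro: both halogens on this ring stand clear of the unsubstituted benzyl of compound 1, and none of the three compounds goes against this. Nothing available explains why the two halogens read alike.

From the compounds shown here alone, it remains open whether a halogen is needed at all, or whether an amine or a carboxylic acid at this place would do as well. Also open, going by these compounds, is whether a longer chain between the sulfur and the ring would keep this level of inhibition.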